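Cytotoxicity notes: trifluoromethyl for chloro on compound 1

This account rests on a few compounds, and the source may have more. Where it says the series, first, only, none or still open, it means among the compounds named here.

Measured compounds:
Compound 1 `CC(=O)OC[C@H]1O[C@H](OC[C@@H](Cn2cc(CN(c3nc(-c4ccc(Cl)cc4)no3)C3CCCCC3)nn2)OC(C)=O)C=C[C@@H]1OC(C)=O`: 35.5 ug/mL
Compound 2 `C#CCN(c1nc(-c2ccc(Cl)cc2)no1)C1CCCCC1`: 15.1 ug/mL

In an ADME assay on RAW264.7 cells (Mus musculus) for cytotoxicity, read by MTT assay, with a stated time of 48 h (a lower number here means that less compound is tolerated, a higher number that more compound is tolerated), compound 1 gives 35.5 ug/mL, the highest of the two numbers. Compound 2 gives 15.1 ug/mL, a lower number, and the gap between the two lies beyond the usual scatter. Within the data shown here, no pair of measured compounds differs in only one place, so no measured step of the kind relevant to compound 3 is available from this set.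

Compound 3 `CC(=O)OC[C@H]1O[C@H](OC[C@@H](Cn2cc(CN(c3nc(-c4ccc(C(F)(F)F)cc4)no3)C3CCCCC3)nn2)OC(C)=O)C=C[C@@H]1OC(C)=O` differs from compound 1 by trifluoromethyl in place of chloro on an aromatic carbon. Nothing measured here shows what trifluoromethyl in place of chloro does in this assay. The step of a 1.2-fold lower number from compound 1 to compound 3 (0.07 log units; within the scatter) is therefore expected to be small, toward a slightly lower number or none beyond the scatter. Compound 3 is estimated at 30 ug/mL, with a range from 15 ug/mL to 60 ug/mL.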

Compound 3, half-maximal cytotoxic concentration: 64.1 ug/mL
Compound 3: middle estimate off by 2.1-fold (0.33 log units), on the low side, outside the stated range (above it).
By their numbers in this assay, from the lowest: compound 2; then compounds 1 and 3 (each within the scatter of the next).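

In this assay, the position para to a large group on the aromatic ring takes trifluoromethyl in place of chloro with a 1.8-fold higher number from compound 1 to compound 3 (0.26 log units; within the scatter), so the two groups cannot be told apart at this position in this assay. Going from 4-chlorophenyl to 4-(trifluoromethyl)phenyl replaces one heavy atom with four, and this exchange leaves the number within the scatter of compound 1. Nothing available explains the size or direction of this step.

The compounds shown leave open whether an amine, a carboxylic acid or a plain hydrogen at this position would give a number beyond the scatter of compound 1. They also leave open whether the same exchange of chloro for trifluoromethyl on compound 2 would give a step of similar size.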